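The compounds below may be only part of what the source reports. "The series", "measured", "known", "first", "only" and "open" are said of these compounds alone.

Compound 1 `COC(=O)c1cccc(-c2ccc([C@H]3S[C@@H](C)C(=O)Nc4c3c(C)nn4-c3ccccc3C)cc2)c1` is the starting point of this account. In an assay on isolated protein for agonist activity at Bile acid receptor (Homo sapiens), read by AlphaScreen, with a stated time of 30 min (a higher number here means that more compound is needed for the effect, a lower number that less compound is needed), compound 1 gives "not active" (no number reported), so no number fixes where it stands, and nothing can be said of its distance from the other compounds. Compound 2 `Cc1nn(-c2ccccc2C(F)(F)F)c2c1C(c1ccc(Oc3ccccc3)cc1)SC(C)C(=O)N2` gives 2000 nM in this assay, and compound 3 `COc1cc([C@H]2S[C@@H](C)C(=O)Nc3c2c(C)nn3-c2ccccc2C)ccc1Oc1ccccc1` gives 1900 nM in this assay; these two values lie within the scatter of each other. Compound 4 `Cc1ccccc1-n1nc(C)c2c1NC(=O)[C@H](C)S[C@@H]2c1ccc(-c2ccco2)cc1` differs from compound 1 in one place: furan-2-yl in place of 3-(methoxycarbonyl)phenyl on an aromatic carbon. For the measured compounds named here, no measured pair shows this change, so its size and direction are unknown, and since compound 1 returned no number, any reported value for compound 4 would mark a gain. Compound 4 is expected to give about 5000 nM in this assay, estimated to fall between 1000 nM and 30000 nM.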

Compound 4, half-maximal effective concentration: 3600 nM
Compound 4: the middle estimate sits 1.4-fold (0.14 log units) above what was measured; the range from low to high includes it.
By their numbers in this assay, from the lowest: compounds 3, 2 and 4 (each within the scatter of the next).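

No step can be read between compound 1 and compound 4: compound 1 carries no number. Nothing available explains the value of compound 4. The compounds shown leave open how large the change from 3-(methoxycarbonyl)phenyl to furan-2-yl is.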